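Trifluoromethyl in Place of Fluoro: Expecting Compound 4

This account rests on a few compounds, and the source may have more. Where it says the series, first, only, none or still open, it means among the compounds named here.

Of the compounds shown here, three sharing one core have been measured in a functional assay on PC-3 cells (Homo sapiens) for cytotoxicity, read by MTT assay, with a stated time of 72 h; a lower number here means a stronger inhibitor, a higher number a weaker inhibitor. Compound 1 `O=S(=O)(c1ccccc1)c1nc2ccccc2nc1Nc1ccccc1` gives 590 nM, compound 2 `COc1ccc(Nc2nc3ccccc3nc2S(=O)(=O)c2ccccc2)cc1` gives 1510 nM, and compound 3 `O=S(=O)(c1ccccc1)c1nc2ccccc2nc1Nc1ccc(F)cc1` gives 14200 nM. Compound 3 therefore stands highest of the three: its nearest neighbour is compound 2, at a 9.4-fold higher number from compound 2 to compound 3 (0.97 log units; beyond the scatter), and its furthest is compound 1, at a 24-fold higher number from compound 1 to compound 3 (1.38 log units; beyond the scatter). The next compound, compound 4 `O=S(=O)(c1ccccc1)c1nc2ccccc2nc1Nc1ccc(C(F)(F)F)cc1`, differs from compound 3 by trifluoromethyl in place of fluoro on an aromatic carbon. The measured steps that bear on this position all describe what happens when that position is changed: hydrogen to methoxy gave a 2.6-fold higher number from compound 1 to compound 2 (0.41 log units; beyond the scatter), hydrogen to fluoro gave a 24-fold higher number from compound 1 to compound 3 (1.38 log units; beyond the scatter), methoxy to fluoro gave a 9.4-fold higher number from compound 2 to compound 3 (0.97 log units; beyond the scatter). Going by the values given here, no step here shows fluoro replaced by trifluoromethyl, so the direction cannot be read off; each substituent tried at this position left the number above that of compound 1. Compound 4 is expected to stay near compound 3, with a step of a 1.2-fold lower number from compound 3 to compound 4 (0.07 log units; within the scatter), and its estimated value in this assay is 12000 nM, between 3000 nM and 50000 nM.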

Compound 4, half-maximal inhibitory concentration: 3550 nM
For compound 4 the middle estimate is 3.4-fold (0.53 log units) above the measured one, and the stated range covers the measured number.
By their numbers in this assay, from the lowest: compound 1; then compound 2; then compound 4; then compound 3.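

In this assay, going by these compounds alone, trifluoromethyl in place of fluoro gives the first step at this position that lowers the number (a 4.0-fold lower number from compound 3 to compound 4 (0.60 log units; beyond the scatter)), so the high number of compound 3 does not extend to every electron-neutral-blind swap of fluoro.

Let me restate this cleanly:

In this assay, within the data shown here, trifluoromethyl in place of fluoro gives the first step at this position that lowers the number (a 4.0-fold lower number from compound 3 to compound 4 (0.60 log units; beyond the scatter)), so the high number of compound 3 is not shared by every halogen-bearing group placed here. Trifluoromethyl still does not reach the unsubstituted ring, however: it stands above methoxy (a 2.4-fold higher number from compound 2 to compound 4 (0.37 log units; beyond the scatter)) and above hydrogen (a 6.0-fold higher number from compound 1 to compound 4 (0.78 log units; beyond the scatter)), which leaves compound 1 with the lowest number among the four, and all three substituents shown here above it. Nothing available gives a cause for these differences.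

From the compounds shown here alone, whether any group at this position could bring the number below that of compound 1 stays open, for instance a nitrile, a chloro group, an amine or a carboxylic acid. Also open, going by these compounds, is whether this order of substituents would hold on the other rings of the shared core.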